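A few compounds are considered here, and "the series" means these few. Any claim that something is new, unique, unknown or untested is made for them only; others in the source may bear on it.

Measured compounds:
Compound 1 `COc1cc(/C=C/C(C)=O)ccc1OCc1cn(-c2ccccc2CO)nn1` — in a functional assay on HCT-116 cells (Homo sapiens) for antiproliferative activity, read by MTT assay, with a stated time of 48 h (a lower number here means a stronger inhibitor, a higher number a weaker inhibitor), compound 1 gives a value that is a limit of the assay, > 100000 nM.
Compound 2 `COc1cc(/C=C/C(C)=O)ccc1OCc1cn(-c2c(Cl)cccc2Cl)nn1` — in this assay compound 2 gives 2000 nM.

Among the measured compounds shown here, compound 2 holds the only actual number among the two values shown; the other is a limit, as noted in the limit of > 100000 nM in this assay, at which 1 of the 2 values shown sits. For the measured compounds named here, the step of an at least 50-fold lower number from compound 1 to compound 2 (1.69 log units; beyond the scatter) is the one measured change on this nitrogen, and it was large.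

Compound 3 `COc1cccc(-n2cc(COc3ccc(/C=C/C(C)=O)cc3OC)nn2)c1` is not yet measured. It differs from compound 2 by 3-methoxyphenyl in place of 2,6-dichlorophenyl on an aromatic nitrogen. Going by the values given here, the single measured step bears on it only indirectly: it shows that the group on this aromatic nitrogen can swing the result strongly, with the 2,6-dichlorophenyl far ahead of the 2-(hydroxymethyl)phenyl. The 3-methoxyphenyl carries no donor, unlike compound 1, but also neither chlorine of compound 2, so a higher number than compound 2 is expected, with a step around a 5.0-fold higher number from compound 2 to compound 3 (0.70 log units; beyond the scatter). Compound 3 is therefore estimated at 10000 nM in this assay, with a likely range from 2500 nM to 60000 nM.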

Compound 3, half-maximal inhibitory concentration: 29600 nM
Beside the measured number, compound 3's estimate is 3.0-fold (0.47 log units) below it; measured number inside the range.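

Exchanging the 2,6-dichlorophenyl for the 3-methoxyphenyl on this aromatic nitrogen gives, in this assay, a 15-fold higher number from compound 2 to compound 3 (1.17 log units; beyond the scatter); both groups have 8 heavy atoms and one six-membered aromatic ring of carbon only, so neither that ring nor the heavy-atom count alone fixes the result. Set against the 2-(hydroxymethyl)phenyl, the same 3-methoxyphenyl gives an at least 3.3-fold lower number from compound 1 to compound 3 (0.52 log units; beyond the scatter), which places it in the middle of the three groups shown, with the 2,6-dichlorophenyl giving the lowest number. This second step can be read only as a bound, because compound 1 stands at a limit of the assay and not at an actual number: the limit of > 100000 nM in this assay, at which 1 of the 3 values shown sits.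

The compounds shown leave open whether the higher number of compound 3 follows from losing the two chlorine atoms, from gaining the methoxy group, or from where the group sits on the phenyl ring, as all of these change together in this one step. Also open, as far as these compounds go, is how an unsubstituted phenyl, a single chlorine, an amine or a carboxylic acid on that ring would read in this assay.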